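From compound 3 to compound 4: a new group on the ring amine

This account rests on a few compounds, and the source may have more. Where it says the series, first, only, none or still open, it means among the compounds named here.

Working notes on the series. Compound 1 `CC(C)(C)OC(=O)N1CCC(O[C@H]2CC[C@@H](Oc3ccc(S(C)(=O)=O)cc3)CC2)CC1` gives 266 nM in a functional assay on isolated protein for agonist activity at Glucose-dependent insulinotropic receptor (Homo sapiens), read by HTRF and cAMP accumulation; a higher number here means that more compound is needed for the effect, a lower number that less compound is needed; its mirror image compound 2 `CC(C)(C)OC(=O)N1CCC(O[C@H]2CC[C@H](Oc3ccc(S(C)(=O)=O)cc3)CC2)CC1` gives 16.1 nM. The step of a 17-fold lower number from compound 1 to compound 2 (1.22 log units; beyond the scatter) rests on (the fact that compounds 1 and 2 differ only in the configuration as drawn). Compound 3 `C[C@H](CF)OC(=O)N1CCC(O[C@H]2CC[C@H](Oc3cnc(S(C)(=O)=O)cn3)CC2)CC1` gives 36.8 nM, the second highest of the three numbers, standing nearer to compound 2 than to compound 1.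

Compound 4 `CC(F)Cc1nc(CN2CCC(O[C@H]3CC[C@H](Oc4cnc(S(C)(=O)=O)cn4)CC3)CC2)no1` differs from compound 3 in one place: a group of 10 heavy atoms (6 carbon, 2 nitrogen, 1 oxygen, 1 fluorine; one five-membered aromatic ring with 3 hetero atoms) in place of a group of 7 heavy atoms (4 carbon, 2 oxygen, 1 fluorine; no ring), on an amine nitrogen in a ring. Within the data shown here, the only measured step, between compound 1 and compound 2, concerns configuration alone and does not bear on this change. Among the measured compounds shown here, with no comparable step available, no shift beyond the scatter is expected, and compound 4 is expected near 40 nM (range 10 nM to 160 nM). The expected step of a 1.1-fold higher number from compound 3 to compound 4 (0.04 log units; within the scatter) is therefore taken as small.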

Compound 4, half-maximal effective concentration: 30.3 nM
Beside the measured number, compound 4's estimate is 1.3-fold (0.12 log units) above it; measured number inside the range.
By their numbers in this assay, from the lowest: compounds 2, 4 and 3 (each within the scatter of the next, the first and the last beyond it); then compound 1.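

On an amine nitrogen in a ring, earlier compounds carried only groups with no ring. In this assay, the (5-(2-fluoropropyl)-1,2,4-oxadiazol-3-yl)methyl group gives a 1.2-fold lower number from compound 3 to compound 4 (0.08 log units; within the scatter), so a five-membered aromatic ring with 3 hetero atoms can stand in this place with no shift beyond the scatter. Nothing known about these compounds bears on this change.

Open, on these data alone, is whether a benzyl group or a carboxylic acid on the same nitrogen would hold this level. Also open, as far as these compounds go, is whether a propyl chain without fluorine on the five-membered ring would do so.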